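Removing the methoxymethyl group from compound 1

A few compounds are considered here, and "the series" means these few. Any claim that something is new, unique, unknown or untested is made for them only; others in the source may bear on it.

Measured compounds:
compound 1, `CCCCCCCCCCCCCC[C@H](OCOC)[C@H](CN(C(C)C)C(C)C)NC(=O)OC(C)(C)C`, 22.6%
compound 2, `CCCCCCCCCCCCCC[C@H](OCOC)[C@H](CN1CCCCC1)NC(=O)OC(C)(C)C`, 19%
compound 3, `CCCCCCCCCCCCCC[C@H](OCOC)[C@H](CN1CCN(C)CC1)NC(=O)OC(C)(C)C`, 18.3%

The three compounds share one core and differ only in the amine on a saturated chain carbon, two bonds along the chain from an amide-type nitrogen. In a functional assay on A549 cells (Homo sapiens) for antiproliferative activity, read by sulforhodamine B assay, with a stated time of 48 h, tested at 10 uM (on this read-out lower numbers stand for less inhibition and higher numbers for more inhibition at the one concentration tested (going by the name of the read-out)), compound 1 gives the highest of the three numbers, yet the step of a number 3.6 percentage points lower from compound 1 to compound 2 (within the scatter) and the step of a number 4.3 percentage points lower from compound 1 to compound 3 (within the scatter) both lie within the usual scatter, so the three compounds cannot be ranked against one another on this read-out.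

Compound 4, `CCCCCCCCCCCCCC[C@H](O)[C@H](CN(C(C)C)C(C)C)NC(=O)OC(C)(C)C`, keeps the diisopropylamino group of compound 1 and changes a different place: hydrogen in place of methoxymethyl on an oxygen on a saturated carbon. Within the data shown here, none of the measured steps touches this part of the molecule; they all exchange the amine and leave the methoxymethyl group in place. Among the measured compounds shown here, no measured step therefore bears on the change from compound 1 to compound 4, and the three measured values, all close to one another, give no basis for expecting a step beyond the scatter in either direction.

Compound 4 is accordingly expected to give about 22% in this assay, with a range from 5% to 45%. As far as these compounds go, the step this estimate implies, a number 0.6 percentage points lower from compound 1 to compound 4 (within the scatter), is expected to stay within the scatter, with the range kept wide to reflect that the change is untested here.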

Compound 4, a percentage reported as inhibition, at one concentration (the size of the read-out at that concentration, not a potency): 22.9%
For compound 4 the middle estimate is 0.9 percentage points below the measured one; the range from low to high includes it.
By their numbers in this assay, from the lowest: compounds 3, 2, 1 and 4 (each within the scatter of the next).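

In this assay, among these compounds, hydrogen in place of methoxymethyl on an oxygen on a saturated carbon gives a number 0.3 percentage points higher from compound 1 to compound 4 (within the scatter), the first measured step at this position rather than at the amine. With the diisopropylamino group in place, the methoxymethyl group is therefore not needed for the level of inhibition that compound 1 shows at the one concentration tested, and the free hydroxy form of compound 4 stands level with it within the scatter. The data shown offer no measurement that could account for this result.

The compounds shown leave open whether the same exchange of methoxymethoxy for hydroxy would stay within the scatter with piperidin-1-yl or 4-methylpiperazin-1-yl on the chain, as compound 2 and compound 3 appear here only with the methoxymethyl group. They also leave open what a methyl or an acetyl group on this oxygen, or a free primary amine at the amide-type nitrogen, would give in this assay.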